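Adding fluoro to a chloro-bearing phenyl ring

The compounds below may be only part of what the source reports. "The series", "measured", "known", "first", "only" and "open" are said of these compounds alone.

In a functional assay on A549 cells (Homo sapiens) for antiproliferative activity, read by MTT assay (a lower number here means a stronger inhibitor, a higher number a weaker inhibitor), compound 1 `Cn1c(=O)c(=O)n(C2CCCC2)c2nc(N/N=C/c3ccccc3)ncc21` gives > 100000 nM as a limit of the assay, not a number. In this assay compound 2 `Cc1cccc(/C=N/Nc2ncc3c(n2)n(C2CCCC2)c(=O)c(=O)n3C)c1` gives 34500 nM and compound 3 `Cn1c(=O)c(=O)n(C2CCCC2)c2nc(N/N=C/c3ccc(Cl)cc3)ncc21` gives 6890 nM as the lowest of the two actual numbers.

Compound 4 `Cn1c(=O)c(=O)n(C2CCCC2)c2nc(N/N=C/c3ccc(F)c(Cl)c3)ncc21` differs from compound 3 in one place, on a carbon with a double bond to nitrogen. There, 3-chloro-4-fluorophenyl stands in place of 4-chlorophenyl, and 3-chloro-4-fluorophenyl in place of 4-chlorophenyl on a carbon with a double bond to nitrogen gives the count of that change.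

Among the compounds with values here, three measured steps bear on it. Exchanging a hydrogen of the phenyl ring for chloro gave an at least 14-fold lower number from compound 1 to compound 3 (1.16 log units; beyond the scatter) as a large step, and methyl in the same kind of exchange gave an at least 2.8-fold lower number from compound 1 to compound 2 (0.46 log units; beyond the scatter) as a smaller one. From the compounds shown here alone, both begin at a limit, so their true sizes remain open. The exchange of 3-methylphenyl for 4-chlorophenyl gave a 5.0-fold lower number from compound 2 to compound 3 (0.70 log units; beyond the scatter) as a modest step.

None of these steps measures a fluoro, and compound 4 keeps a chloro, so only a small move to a lower number is expected in this assay here. The estimated change is a 1.5-fold lower number from compound 3 to compound 4 (0.19 log units; within the scatter) and is expected to stay within the usual scatter. The expected value for compound 4 is 4500 nM with an estimated range from 1700 nM to 12000 nM around it.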

Compound 4, half-maximal inhibitory concentration: 9410 nM
Estimate against measurement, compound 4: 2.1-fold (0.32 log units) below; the range from low to high includes it.
By their numbers in this assay, from the lowest: compounds 3 and 4 (each within the scatter of the next); then compound 2. At a limit, above all of these: compound 1.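

In this assay, the step from 4-chlorophenyl to 3-chloro-4-fluorophenyl gives a 1.4-fold higher number from compound 3 to compound 4 (0.14 log units; within the scatter), so at this position, on a carbon with a double bond to nitrogen, the two rings cannot be told apart, even though the names show that the change is more than an added fluoro. The new ring also keeps a clear distance from the 3-methylphenyl of the earlier compound, with a 3.7-fold lower number from compound 2 to compound 4 (0.56 log units; beyond the scatter), so a second chloro-bearing ring now stands apart from that methyl-bearing ring. Compound 1 sits at a limit of the assay, not a number, so an at least 10-fold lower number from compound 1 to compound 4 (1.02 log units; beyond the scatter) gives only the smallest size that this step can have: the limit of > 100000 nM in this assay, at which 1 of the 4 values shown sits.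

The rings shown carry only chloro, fluoro and methyl, so it remains open how a ring bearing an amine, a carboxylic acid or a methoxy group would behave at this position. From the compounds shown here alone, it is also open what fluoro does on the phenyl ring without any chloro, and what 3-chlorophenyl alone would give, since the effects of the fluoro and of the chloro's place are not separated here.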